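This account rests on a few compounds, and the source may have more. Where it says the series, first, only, none or still open, it means among the compounds named here.

Working notes on the series sharing the core seen in compound 2 `COC(=O)C1=C(C)NC(=O)NC1c1ccc(O)cc1`.

In an assay for inhibition of beta-glucuronidase (Bos taurus), read by spectrophotometry, with a stated time of 30 min (a lower number here means a stronger inhibitor, a higher number a weaker inhibitor), compound 2 gives 17200 nM, the lowest of the two numbers recorded. Going by the values given here, its nearest neighbour is compound 3 `COC(=O)C1=C(C)NC(=O)NC1c1ccc(O)c(Cl)c1`, which gives 27200 nM; the only single-site step measured so far, a 1.6-fold higher number from compound 2 to compound 3 (0.20 log units; within the scatter), is chloro in place of hydrogen on an aromatic carbon. Compound 1 `COC(=O)C1=C(C)NC(=O)NC1c1ccc(OC)c(OCc2ccccc2)c1` is reported as "not active" (no number reported), without a number.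

Compound 4 `COC(=O)C1=C(C)NC(=O)NC1c1ccc(C(C)C)cc1` is not yet measured. The change from compound 2 is isopropyl in place of hydroxy on an aromatic carbon, on an aromatic carbon of the six-membered carbon ring, para to a large group. Among the compounds with values here, no measured step bears directly on it: the one step known, from compound 2 to compound 3, lies within the scatter and concerns a different substituent. Within the data shown here, compound 1 shows that another alteration at this ring removed measurable activity, but no step to it can be counted. For compound 4 a step of a 1.7-fold higher number from compound 2 to compound 4 (0.24 log units; within the scatter) is therefore expected, with an open direction and a real chance of no number being reported. The estimate for compound 4 in this assay is 30000 nM, in the range 10000 nM to 100000 nM.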

Compound 4, half-maximal inhibitory concentration: "not active" (no number reported)
The entry for compound 4 holds no number; the estimate stays without a comparison.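

In this assay, going by these compounds alone, compound 4 gives "not active" (no number reported) and so no step from compound 2 to compound 4 can be read. The compounds shown leave open whether the hydroxy present in compound 2 and compound 3 is required for a measurable number. No available evidence bears on this result.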